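This account rests on a few compounds, and the source may have more. Where it says the series, first, only, none or still open, it means among the compounds named here.

Measured compounds:
compound 1 `COc1nc(-c2ccccc2)cc(-c2ccc(F)cc2)c1C#N`: 25 nM
compound 2 `COc1nc(-c2ccccc2)cc(-c2ccc(Cl)cc2)c1C#N`: 252 nM
compound 3 `COc1nc(-c2ccncc2)cc(-c2ccc(F)cc2)c1C#N`: 17400 nM

In an assay on isolated protein for inhibition of sulfide:quinone oxidoreductase, mitochondrial (Homo sapiens) (a lower number here means a stronger inhibitor, a higher number a weaker inhibitor), compound 1 gives the lowest of the three numbers; compound 2 is nearest (a 10-fold higher number from compound 1 to compound 2 (1.00 log units; beyond the scatter)) and compound 3 furthest (a 700-fold higher number from compound 1 to compound 3 (2.84 log units; beyond the scatter)). Compound 4 `COc1nc(-c2ccccn2)cc(-c2ccc(F)cc2)c1C#N` is the untested analogue; it differs from compound 1 in that (pyridin-2-yl in place of phenyl on an aromatic carbon). The step that bears on it most is a 700-fold higher number from compound 1 to compound 3 (2.84 log units; beyond the scatter), where the same phenyl gave way to a pyridin-4-yl; the chloro step a 10-fold higher number from compound 1 to compound 2 (1.00 log units; beyond the scatter) touches a different ring. Among the compounds with values here, no measured step carries pyridin-2-yl. Within the data shown here, a loss beyond the scatter is therefore expected in this assay, though plausibly smaller than the one seen for compound 3. Compound 4 is expected to give 2000 nM, between 200 nM and 20000 nM. The expected step is an 80-fold higher number from compound 1 to compound 4 (1.90 log units; beyond the scatter).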

Compound 4, half-maximal inhibitory concentration: 14 nM
Estimate against measurement, compound 4: 140-fold (2.15 log units) above, outside the stated range (below it).
By their numbers in this assay, from the lowest: compounds 4 and 1 (each within the scatter of the next); then compound 2; then compound 3.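

In this assay, a ring nitrogen on this aromatic carbon carries no cost in itself when it sits as pyridin-2-yl (a 1.8-fold lower number from compound 1 to compound 4 (0.25 log units; within the scatter)), so the loss at compound 3 does not extend to every pyridine here. The placement of the nitrogen within the entering ring separates the two pyridines (a 1200-fold lower number from compound 3 to compound 4 (3.09 log units; beyond the scatter)), with compound 3 alone among the pyridines showing the loss. Nothing available explains this difference between pyridin-2-yl and pyridin-4-yl. As far as these compounds go, whether pyridin-3-yl follows compound 4 or compound 3 remains open. So does whether a phenyl bearing an amine at this position keeps the activity of compound 1.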